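The compounds below may be only part of what the source reports. "The series", "measured", "known", "first", "only" and "open" are said of these compounds alone.

Of the compounds shown here, two have been tested so far, both built on the same core that carries a phenyl-bearing ring system joined to a second, oxygen-containing bicyclic unit. Compound 1 `O=c1cc(-c2ccccc2)oc2ccc(N3COc4c(cccc4[N+](=O)[O-])C3)cc12` carries a nitro group on that unit, while compound 2 `O=c1cc(-c2ccccc2)oc2ccc(N3COc4c(Cl)cc(Cl)cc4C3)cc12` carries two chlorines. In a functional assay on MCF7 cells (Homo sapiens) for inhibition, read by MTT assay, with a stated time of 48 h, tested at 15 ug/mL (a lower number here means less inhibition of growth, a higher number more inhibition of growth at the concentration tested), compound 1 gives 55.9%, and compound 2 gives 61.3%. Compound 1 thus stands lowest of the two numbers, but compound 2 lies within the usual scatter of it, so the two cannot be told apart.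

The next compound, compound 3 `Cc1cccc2c1OCN(c1ccc3oc(-c4ccccc4)cc(=O)c3c1)C2`, differs from compound 1 in one place: methyl in place of nitro on an aromatic carbon. Going by the values given here, no measured pair shows what such a swap does here. With nothing to go on beyond the small spread seen so far, the expected step of a number 0.9 percentage points lower from compound 1 to compound 3 (within the scatter) is none beyond the scatter. Compound 3 is therefore estimated at 55%, within 40% to 70%.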

Compound 3, percent growth inhibition at one concentration: 60.9%
The estimate for compound 3 lay 5.9 percentage points below the measured number; measured number inside the range.
By their numbers in this assay, from the lowest: compounds 1, 3 and 2 (each within the scatter of the next).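

In this assay, going by these compounds alone, placing methyl instead of nitro on this aromatic carbon gives a number 5 percentage points higher from compound 1 to compound 3 (within the scatter) and is the first comparison in which only one place changes. Nitro carries hydrogen-bond acceptors and methyl carries none, yet this difference leaves the two compounds indistinguishable in this read-out, so at this position the swap shows no clear effect on growth inhibition at the concentration tested. No independent measurement is available to explain this result.

On these data alone, it remains open whether an amine, a carboxylic acid or a longer chain on this aromatic carbon would shift the number beyond the scatter. A single concentration also leaves open whether compound 1 and compound 3 would still match at other doses.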